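From Cyclohexylamide to Morpholine Amide in Paw Edema

The source may hold more compounds than are shown below. What is called first, only, known or untested is meant among the compounds shown, and "the series" means these compounds.

Compound 1 `COc1cc2c(cc1OC)C(CC(=O)NC1CCCC1)CC2`: 52%
Compound 2 `COc1cc2c(cc1OC)C(CC(=O)NC1CCCCC1)CC2`: 56%

In a functional assay on the whole organism (strain Wistar) for inhibition, with Rattus norvegicus as the target, read by paw edema, with stated times of 60 min and 2 h, at a dose of 100 mg/kg by the oral route (on this read-out lower numbers stand for less inhibition and higher numbers for more inhibition at the one dose given (going by the name of the read-out)), compound 2 gives 56%, the larger of the two numbers, though only by a number 4 percentage points higher from compound 1 to compound 2 (within the scatter). Compound 3 `COc1cc2c(cc1OC)C(CC(=O)N1CCOCC1)CC2` brings a different kind of change: morpholin-4-yl in place of cyclohexylamino on a carbonyl carbon. Within the data shown here, the one measured step only swaps one carbon-only ring for another on the amide nitrogen and says nothing about losing the hydrogen-bond donor, so no measured step bears on this change. With that thin support, compound 3 is expected to give 50%, ranging from 35% to 65%, a step of a number 6 percentage points lower from compound 2 to compound 3 (within the scatter) that is estimated to stay within the scatter.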

Compound 3, a percentage reported as inhibition, in the whole organism at one dose (the size of the read-out at that dose, not a potency): 14%
Compound 3: middle estimate off by 36 percentage points, on the high side; the whole stated range lies above it.
By their numbers in this assay, from the lowest: compound 3; then compounds 1 and 2 (each within the scatter of the next).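

The carbonyl carbon is not indifferent to every change: morpholin-4-yl in place of cyclohexylamino gives a number 42 percentage points lower from compound 2 to compound 3 (beyond the scatter), and in place of cyclopentylamino it gives a number 38 percentage points lower from compound 1 to compound 3 (beyond the scatter). Both steps lie beyond the scatter, unlike the swap between the two carbon-only rings. Nothing measured here explains this drop.

Going by these compounds, the amide hydrogen and the ring oxygen change together, so their separate contributions remain open. A piperidin-1-yl group or a tetrahydropyran-4-ylamino group on the same carbonyl carbon would separate them.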